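Aryl group variation at the saturated ring carbon

The compounds below may be only part of what the source reports. "The series", "measured", "known", "first", "only" and "open" are said of these compounds alone.

Measured compounds:
Compound 1 `CC(C)[C@H](NC(=O)CCN(C)C)c1cccc(F)c1N1CCN(C(=O)[C@@H]2CN(C(C)C)C[C@H]2c2ccc(Cl)cc2)CC1`: 5.3 nM in an assay on HEK293 cells for displacement of a labelled ligand from Melanocortin receptor 4 (Homo sapiens); on this read-out lower numbers stand for stronger inhibition and higher numbers for weaker inhibition
Compound 2 `Cc1cccc([C@@H]2CN(C(C)C)C[C@H]2C(=O)N2CCN(c3c(F)cccc3[C@@H](NC(=O)CCN(C)C)C(C)C)CC2)c1`: 470 nM in this assay
Compound 3 `CC(C)[C@H](NC(=O)CCN(C)C)c1cccc(F)c1N1CCN(C(=O)[C@@H]2CN(C(C)C)C[C@H]2c2cccc(F)c2)CC1`: 560 nM in this assay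

Compound 3 has the highest of the three numbers measured in this assay. The step of a 1.2-fold higher number from compound 2 to compound 3 (0.08 log units; within the scatter) lies within the scatter, whereas the step of a 110-fold higher number from compound 1 to compound 3 (2.02 log units; beyond the scatter) is large and well beyond it.

Compound 4 `CC(C)[C@H](NC(=O)CCN(C)C)c1cccc(F)c1N1CCN(C(=O)[C@@H]2CN(C(C)C)C[C@H]2c2ccc(C(F)(F)F)cc2F)CC1` has not been measured. It differs from compound 3 in one place: 2-fluoro-4-(trifluoromethyl)phenyl in place of 3-fluorophenyl on a saturated ring carbon. Going by the values given here, two measured steps bear on this position. Both an 89-fold higher number from compound 1 to compound 2 (1.95 log units; beyond the scatter) and a 110-fold higher number from compound 1 to compound 3 (2.02 log units; beyond the scatter) show that replacing the 4-chlorophenyl of compound 1 with 3-methylphenyl or 3-fluorophenyl raises the number a great deal. Compound 4 returns a group at the place where compound 1 carries its chloro, now a trifluoromethyl, and adds a further fluoro. Among the compounds with values here, no measured pair shows what a trifluoromethyl or the additional fluoro does on its own, so the expectation rests only on the pattern seen in compound 1 against compounds 2 and 3. A large step downward is expected, a 37-fold lower number from compound 3 to compound 4 (1.57 log units; beyond the scatter), though compound 1 may not be matched. Compound 4 is therefore estimated to give about 15 nM, within a range of 3 nM to 80 nM.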

Compound 4, inhibition constant: 61 nM
The estimate for compound 4 lay 4.1-fold (0.61 log units) below the measured number, within the range that was stated.
By their numbers in this assay, from the lowest: compound 1; then compound 4; then compounds 2 and 3 (each within the scatter of the next).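

In this assay, the 2-fluoro-4-(trifluoromethyl)phenyl group shows that the number at this saturated ring carbon can come back down from the level of the two 3-substituted aryl groups, with a 9.2-fold lower number from compound 3 to compound 4 (0.96 log units; beyond the scatter) and a 7.7-fold lower number from compound 2 to compound 4 (0.89 log units; beyond the scatter) as the two steps beyond the scatter. The recovery is only partial, as a 12-fold higher number from compound 1 to compound 4 (1.06 log units; beyond the scatter) leaves 4-chlorophenyl with the lowest number of the four compounds, so a substituent at the 4-place of the aryl name does not by itself restore the number of compound 1. Across these four compounds, the two aryl groups with a 4-substituent give lower numbers than 3-methylphenyl and 3-fluorophenyl, with no compound going against this, but no measurement shown gives a reason for the difference.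

The compounds shown do not separate the trifluoromethyl from the added fluoro, which 4-(trifluoromethyl)phenyl and 2-fluoro-4-chlorophenyl would do. Also open, on these data alone, is how other groups behave at this carbon, such as 4-methoxyphenyl or a pyridyl ring.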